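The source may hold more compounds than are shown below. What is called first, only, known or untested is meant among the compounds shown, and "the series" means these compounds.

- compound 1 `NCCCCN(C[C@H]1Cc2cccnc2CN1)[C@H]1CCCc2cccnc21` gives 69%
- compound 2 `CN(C[C@@H]1Cc2ncccc2CN1)[C@H]1CCCc2cccnc21` gives 0%
- compound 3 `NC/C=C/CN(C[C@H]1Cc2ncccc2CN1)[C@H]1CCCc2cccnc21` gives 37%

These three values come from an ADME assay on microsomes from liver (Mus musculus) for metabolic stability, using NADPH, with a stated time of 10 min; on this read-out lower numbers stand for a less stable compound and higher numbers for a more stable compound. Among them, compound 3 at 37% holds the second highest number. Compound 1 lies above it and compound 2 lies below it, and both gaps are beyond the usual scatter of repeated measurements.

The next compound to be tested is compound 4 `NC(=O)NC/C=C/CN(C[C@H]1Cc2ncccc2CN1)[C@H]1CCCc2cccnc21`. It is made from compound 3 by a single change: carbamoyl in place of hydrogen on an amine nitrogen. In other words, the amino group becomes a ureido group, and the rest of the structure stays as it was.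

Among the compounds with values here, no two measured compounds differ in one place only, so the data contain no direct precedent for this change. Within the data shown here, the only firm anchor is compound 3 at 37%, a middle value with room to move either way. The expected result is therefore a small rise, a number 8 percentage points higher from compound 3 to compound 4 (within the scatter), and this estimate may well prove to lie within the scatter. For compound 4 the estimated value is 45%, with an expected range from 20% to 72%.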

Compound 4, percent of the compound remaining: 19%
Compound 4: middle estimate off by 26 percentage points, on the high side; measured number below the stated range.
By their numbers in this assay, from the lowest: compound 2; then compound 4; then compound 3; then compound 1.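

Turning the amino group into a ureido group gives the one step here that changes a single place, and in this assay it reads a number 18 percentage points lower from compound 3 to compound 4 (beyond the scatter) for carbamoyl in place of hydrogen on this amine nitrogen. The change is therefore not neutral at this position: on a nitrogen whose other neighbour is a saturated chain carbon, the added carbamoyl goes with less of the compound remaining. This step lies beyond the usual scatter of repeated measurements. This rests on a single modest step, so it gives a direction for this pair and not a rule for the series, and no measurement shown bears on why the number fell.

As far as these compounds go, it remains open whether the fall follows from the whole ureido group or simply from replacing a hydrogen on the free amino group, a question that an acetyl group or a methyl group on the same nitrogen could help to settle. From the compounds shown here alone, it also remains open whether carbamoyl at the end of the saturated chain of compound 1 would give a step of similar direction and size.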